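Nitro to Fluoro: Estimating Compound 3

The source may report more compounds than this note shows. Statements on the series, on what has been measured and on what is new or still open speak of the compounds shown alone.

Measured compounds:
compound 1 `COc1cc(OC)c2c(=O)cc(C(=O)Nc3ccc(C4CCCCC4)cc3)[nH]c2c1`, "not determined" (no result reported);
compound 2 `COc1cc(OC)c2c(=O)cc(C(=O)Nc3ccc(Oc4ccc([N+](=O)[O-])cc4)cc3)[nH]c2c1`, 480 nM.

Going by the values given here, in a functional assay on SEM cells (Homo sapiens) for antiproliferative activity, with a stated time of 72 h (on this read-out lower numbers stand for an effect already at smaller amounts and higher numbers for an effect only at larger amounts of compound), compound 2 gives 480 nM, the only number in this small set, as compound 1 has "not determined" (no result reported). Compound 3 `COc1cc(OC)c2c(=O)cc(C(=O)Nc3ccc(Oc4ccc(F)cc4)cc3)[nH]c2c1` differs from compound 2 by fluoro in place of nitro on an aromatic carbon. Among the compounds with values here, no measured pair shows this change, so nothing here tells how large its effect is. The expectation is a small step in this assay, if anything toward higher concentrations, likely within the usual scatter. Compound 3 is therefore expected at 650 nM, with a range from 200 nM to 2000 nM. The step from compound 2 to compound 3 is estimated as a 1.4-fold higher number from compound 2 to compound 3 (0.13 log units; within the scatter).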

Compound 3, half-maximal effective concentration: > 50000 nM
Compound 3 gave a limit, no number; the forecaster's own chance of this, stated with the estimate: 5%; middle value at least 76-fold (1.88 log units) from the limit.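

In this assay, fluoro in place of nitro on this aromatic carbon, para to a large group, is no small change: it gives an at least 100-fold higher number from compound 2 to compound 3 (2.01 log units; beyond the scatter). Going by these compounds alone, with only one number available earlier, nothing showed that this position could matter so much. The result for compound 3 is a limit, not a number, so the true size of the step stays unknown: the limit of > 50000 nM in this assay, at which 1 of the 3 values shown sits.

Only nitro and fluoro can be compared at this position. Going by these compounds, how an amine, a nitrile or a carboxylic acid would behave there remains open, as does whether any other group keeps the activity of compound 2.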